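Shortening the aryl ether chain: compound 3 to compound 4

A few compounds are considered here, and "the series" means these few. Any claim that something is new, unique, unknown or untested is made for them only; others in the source may bear on it.

Measured compounds:
Compound 1, `O=C(O)c1csc([C@H]2CC[C@@H]3[C@@H](COc4ccccc4F)[C@H](O)C[C@@H]3O2)n1`: in a functional assay on CHO cells for agonist activity at prostaglandin E2 receptor EP2 subtype (Homo sapiens), read by HTRF and cAMP accumulation, with a stated time of 30 min (a higher number here means that more compound is needed for the effect, a lower number that less compound is needed), compound 1 gives 23 nM.
Compound 2, `Cc1ccc(OC[C@@H]2[C@H]3CC[C@H](c4nc(C(=O)O)cs4)O[C@H]3C[C@H]2O)cc1`: compound 2 gives 27 nM.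
Compound 3, `O=C(O)c1csc([C@H]2CC[C@@H]3[C@@H](CCCCCOc4ccccc4)[C@H](O)C[C@@H]3O2)n1`: compound 3 gives 28 nM.

Compound 3 carries the highest number of the three, yet its gaps to compound 2 and to compound 1 lie within the scatter, so no order among them can be read. For the measured compounds named here, the only single-point step, a 1.2-fold higher number from compound 1 to compound 2 (0.07 log units; within the scatter), is within the scatter and concerns the aryl group, not the chain. Compound 4, `O=C(O)c1csc([C@H]2CC[C@@H]3[C@@H](CCCOc4ccccc4)[C@H](O)C[C@@H]3O2)n1`, differs from compound 3 by phenoxy in place of 2-phenoxyethyl on a saturated chain carbon, three bonds along the chain from a saturated ring carbon. Going by the values given here, no measured pair isolates this change; compounds 1 and 2 hold a shorter aryl ether chain than compound 3, and all three values sit together within the scatter. The expectation for a 1.1-fold lower number from compound 3 to compound 4 (0.05 log units; within the scatter) is therefore no step beyond the scatter. Compound 4 is estimated at 25 nM, between 10 nM and 65 nM.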

Compound 4, half-maximal effective concentration: 10 nM
Compound 4: the middle estimate sits 2.5-fold (0.40 log units) above what was measured; measured number inside the range.
By their numbers in this assay, from the lowest: compound 4; then compounds 1, 2 and 3 (each within the scatter of the next).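

In this assay, for the compounds shown here, this chain position proves sensitive: phenoxy in place of 2-phenoxyethyl gives the first step beyond the scatter (a 2.8-fold lower number from compound 3 to compound 4 (0.45 log units; beyond the scatter)). Compound 4 also separates from the two compounds with substituted aryl ethers (a 2.7-fold lower number from compound 2 to compound 4 (0.43 log units; beyond the scatter); a 2.3-fold lower number from compound 1 to compound 4 (0.36 log units; beyond the scatter)), though all three steps are modest. No evidence on hand accounts for these steps.

Still open, as far as these compounds go, is whether the lower number of compound 4 holds with an amine in place of the ether oxygen. A fluorine on the phenyl ring of compound 4 would also test whether the chain and aryl changes act independently.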